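Methyl on the aromatic carbon of compound 3: working notes

The source may hold more compounds than are shown below. What is called first, only, known or untested is meant among the compounds shown, and "the series" means these compounds.

compound 1 `CC(=O)N(C)CC#CCn1cncc1C`: 45 mg/kg
compound 2 `COC(=O)NCC#CCn1cncc1C`: > 100 mg/kg, a limit
compound 3 `COC(=O)N(C)CC#CCn1ccnc1`: 4.5 mg/kg

In a functional assay on the whole organism for agonist activity, with Mus musculus as the target (on this read-out higher numbers stand for an effect only at larger amounts of compound and lower numbers for an effect already at smaller amounts), compound 3 holds the lower of the two exact numbers, 4.5 mg/kg; compound 1 follows at 45 mg/kg, a gap beyond the scatter. Compound 2 sits at a limit, > 100 mg/kg. Compound 4 `COC(=O)N(C)CC#CCn1cncc1C` differs from compound 3 by methyl in place of hydrogen on an aromatic carbon. For the measured compounds named here, no measured step isolates this change. Going by the values given here, the one measured step, an at least 2.2-fold higher number from compound 1 to compound 2 (0.34 log units; beyond the scatter), lies at the chain end and bears on it only indirectly. Compound 1 shares the added methyl and gives 45 mg/kg, though it also differs from compound 3 at the chain end. A rise in the number beyond the scatter is therefore expected. The expected step is a 4.4-fold higher number from compound 3 to compound 4 (0.65 log units; beyond the scatter). For compound 4 the estimated value is 20 mg/kg, with an expected range from 6 mg/kg to 80 mg/kg.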

Compound 4, dose for half-maximal effect: > 100 mg/kg
Compound 4 ended at the assay's limit; the forecaster's own chance of this, stated with the estimate: 10%; at least 5.0-fold (0.69 log units) between middle value and limit.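

In this assay, methyl in place of hydrogen on an aromatic carbon, next to the ring nitrogen and next to the ring atom that bears a large group, now has a measured step of its own (an at least 22-fold higher number from compound 3 to compound 4 (1.34 log units; beyond the scatter)). Compound 4 sits at a limit of the assay (> 100 mg/kg). With that methyl present, methoxy in place of methyl on a carbonyl carbon also shifts the read-out (an at least 2.2-fold higher number from compound 1 to compound 4 (0.34 log units; beyond the scatter)), so compound 1 was no clean guide to this change.

On these data alone, whether ethyl or an amine on that aromatic carbon would behave like methyl stays open. The step between compound 2 and compound 4 cannot be read: the limit of > 100 mg/kg in this assay, at which 2 of the 4 values shown sit.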